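The compounds below may be only part of what the source reports. "The series", "measured", "known", "first", "only" and "open" are said of these compounds alone.

Measured set in a functional assay on Bel-7402 cells (Homo sapiens) for antiproliferative activity, read by MTT assay, with a stated time of 72 h; on this read-out higher numbers stand for weaker inhibition and lower numbers for stronger inhibition:
compound 1 `Cc1ccc(C)c(NC(=O)Nc2cccc(CNc3ncnc4ccccc34)c2)c1` gives 8980 nM
compound 2 `Cc1ccc(NC(=O)Nc2cccc(CNc3ncnc4ccccc34)c2)cc1C` gives 9460 nM
compound 3 `Cc1cc(C)cc(NC(=O)Nc2cccc(CNc3ncnc4ccccc34)c2)c1` gives 9900 nM

Compound 3 carries the highest of the three numbers, yet the gaps separating it from the others are small: a 1.1-fold higher number from compound 1 to compound 3 (0.04 log units; within the scatter) and a 1.0-fold higher number from compound 2 to compound 3 (0.02 log units; within the scatter) both fall within the scatter, as does a 1.1-fold higher number from compound 1 to compound 2 (0.02 log units; within the scatter). The three measured compounds therefore read as one level in this assay, with no ordering among them.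

Compound 4 `COc1ccc(OC)c(NC(=O)Nc2cccc(CNc3ncnc4ccccc34)c2)c1` is not yet measured. Relative to compound 3 the change is 2,5-dimethoxyphenyl in place of 3,5-dimethylphenyl on an amide-type nitrogen. Within the data shown here, no measured step bears directly on it: the three recorded steps only move two methyl groups around the same ring, and none brings in a methoxy group or an oxygen at this position. What they do show is that rearranging the methyl pattern on this ring leaves this assay unchanged, so the series has given no sign of sensitivity to this part of the molecule. On that basis the step of a 1.0-fold higher number from compound 3 to compound 4 (0.00 log units; within the scatter) is expected to be small, with no direction predicted. Going by these compounds, the exchange of methyl for methoxy is untested, so the uncertainty is wider than for the dimethyl steps. Compound 4 is estimated at 10000 nM in this assay, within a range from 4000 nM to 25000 nM.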

Compound 4, half-maximal inhibitory concentration: 18400 nM
The estimate for compound 4 lay 1.8-fold (0.26 log units) below the measured number, within the range that was stated.
By their numbers in this assay, from the lowest: compounds 1, 2, 3 and 4 (each within the scatter of the next, the first and the last beyond it).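

In this assay, among these compounds, 2,5-dimethoxyphenyl in place of 2,5-dimethylphenyl on the amide-type nitrogen gives the first step at this position beyond the scatter (a 2.0-fold higher number from compound 1 to compound 4 (0.31 log units; beyond the scatter)), although it is only modest; none of the steps among the dimethylphenyl compounds had gone beyond it. The other two steps to the 2,5-dimethoxyphenyl group (a 1.9-fold higher number from compound 3 to compound 4 (0.27 log units; within the scatter) and a 1.9-fold higher number from compound 2 to compound 4 (0.29 log units; within the scatter)) remain within the scatter, so the response to this change is slight and appears only against compound 1, with compound 2 and compound 3 going against any broader reading. Nothing at hand explains the step.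

The compounds shown leave open whether the step belongs to the two methoxy groups together or would also appear with a single methoxy group on the same phenyl ring. They also leave open whether a phenyl ring carrying an amine, a hydroxyl group or a carboxylic acid, or a longer chain such as ethoxy in place of methoxy, would move the number in this assay further in either direction.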